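The source may hold more compounds than are shown below. What is called first, only, known or untested is meant among the compounds shown, and "the series" means these compounds.

Working notes on the series. Compound 1 `CN1C/C(=C\c2ccccc2)C(=O)[C@]2(C1)[C@@H](c1ccccc1)CN(C)[C@@]21C(=O)Nc2ccccc21` gives 71.4% in a functional assay on the whole organism (strain Wister albino) for inhibition, with Rattus norvegicus as the target, read by paw edema, with stated times of 1 h and 3 h, at a dose of 50 mg/kg by the intraperitoneal route (on this read-out lower numbers stand for less inhibition and higher numbers for more inhibition at the one dose given (going by the name of the read-out)), and stands second highest of the three numbers measured. Compound 2 `CN1C/C(=C\c2ccccc2)C(=O)[C@]2(C1)[C@@H](c1ccccc1)CN(C)[C@@]21C(=O)N(C)c2ccccc21` gives 75.6%; the step of a number 4.2 percentage points higher from compound 1 to compound 2 (within the scatter) carries methyl in place of hydrogen on an amide-type nitrogen in a ring. Among the compounds with values here, compound 3 `CN1C/C(=C\c2ccc(Cl)cc2)C(=O)[C@]2(C1)[C@@H](c1ccc(Cl)cc1)CN(C)[C@@]21C(=O)N(C)c2ccccc21` gives 44.5%, well under compound 1, though no single-place step links it to compound 1 or compound 2. Compound 4 `COc1ccc(/C=C2\CN(C)C[C@@]3(C2=O)[C@@H](c2ccccc2)CN(C)[C@@]32C(=O)Nc3ccccc32)cc1` differs from compound 1 by methoxy in place of hydrogen on an aromatic carbon. Within the data shown here, no measured step touches an aromatic carbon, so nothing directly bears on this change; the one measured step stayed within the scatter. A step within the scatter, a number 5.4 percentage points lower from compound 1 to compound 4 (within the scatter), is therefore expected. Compound 4 is estimated at 66%, ranging from 52% to 80%.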

Compound 4, a percentage reported as inhibition, in the whole organism at one dose (the size of the read-out at that dose, not a potency): 76.5%
The estimate for compound 4 lay 10.5 percentage points below the measured number; the measured number falls inside the stated range.
By their numbers in this assay, from the lowest: compound 3; then compounds 1, 2 and 4 (each within the scatter of the next).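

Methoxy in place of hydrogen on an aromatic carbon, para to a large group, gives the first measured step at such a carbon: in this assay phenyl to 4-methoxyphenyl amounts to a number 5.1 percentage points higher from compound 1 to compound 4 (within the scatter) at the one dose given. On this single pair, the change leaves the read-out within the usual scatter. Nothing at hand gives a cause for this result.

Still open, as far as these compounds go, is how an amine, a carboxylic acid or an ethoxy group at this place would read. Also open, from the compounds shown here alone, is whether methoxy would read alike on the other aromatic rings of the shared core.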